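Compound 2 and the step to a single hydroxy

A few compounds are considered here, and "the series" means these few. Any claim that something is new, unique, unknown or untested is made for them only; others in the source may bear on it.

Measured in a physicochemical assay, read by spectrophotometry, with a stated time of 30 min; a higher number here means a weaker inhibitor, a lower number a stronger inhibitor:
Compound 1 `O=C(CCc1nc2ccccc2c(=O)[nH]1)N/N=C/c1ccc(O)c(O)c1`: 113000000 nM
Compound 2 `O=C(CCc1nc2ccccc2c(=O)[nH]1)N/N=C/c1ccc([N+](=O)[O-])cc1`: 328000000 nM

Of these two, compound 2 has the higher number, so it is the weaker inhibitor. The next structure is compound 3 `O=C(CCc1nc2ccccc2c(=O)[nH]1)N/N=C/c1ccc(O)cc1`, which differs from compound 2 at one place (hydroxy in place of nitro on an aromatic carbon). Hydroxy stands in place of nitro on an aromatic carbon, giving 4-hydroxyphenyl in place of 4-nitrophenyl.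

Among the compounds with values here, only one measured step bears on this change (a 2.9-fold higher number from compound 1 to compound 2 (0.46 log units; beyond the scatter)). That modest step, beyond the scatter, put 4-nitrophenyl in place of 3,4-dihydroxyphenyl. Removing the nitro again and restoring a hydroxy should therefore lower the number by a similar or smaller amount. In this assay the expected change is a 2.1-fold lower number from compound 2 to compound 3 (0.31 log units; beyond the scatter) and remains modest. Compound 3 is estimated at 160000000 nM (expected range 70000000 nM to 350000000 nM).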

Compound 3, half-maximal inhibitory concentration: 238000000 nM
Beside the measured number, compound 3's estimate is 1.5-fold (0.17 log units) below it, and the stated range covers the measured number.
By their numbers in this assay, from the lowest: compound 1; then compounds 3 and 2 (each within the scatter of the next).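

In this assay, exchanging nitro for hydroxy at this ring position gives a 1.4-fold lower number from compound 2 to compound 3 (0.14 log units; within the scatter), so this assay does not separate the 4-nitrophenyl and 4-hydroxyphenyl compounds. Removing one hydroxy from the 3,4-dihydroxyphenyl group matters more, with a 2.1-fold higher number from compound 1 to compound 3 (0.32 log units; beyond the scatter), a modest change but one beyond the scatter, so among these three compounds only compound 1, with both hydroxy groups, stands apart. Nothing available explains why the second hydroxy goes with this difference.

As far as these compounds go, it remains open whether an amine or a methoxy at this ring position would give a number close to those of compound 2 and compound 3 or one closer to that of compound 1. It is also unknown whether methoxy in place of either hydroxy of compound 1 would keep its lower number.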